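The source may hold more compounds than are shown below. What is called first, only, known or untested is meant among the compounds shown, and "the series" means these compounds.

Working notes on the series, read in an ADME assay on HEK293 cells (Homo sapiens) for antiproliferative activity, read by MTT assay; a higher number here means a weaker inhibitor, a lower number a stronger inhibitor. Compound 1 `Nc1c(C(=O)N/N=C/c2ccc(Br)cc2)oc2nc(-c3cccs3)cc(C(F)(F)F)c12` gives 86000 nM, and compound 2 `Nc1c(C(=O)N/N=C/c2ccc(Cl)cc2)oc2nc(-c3cccs3)cc(C(F)(F)F)c12` gives 83000 nM. The two values sit within the scatter of each other, so compound 2 has no separate standing on these numbers. Compound 3 `CCNC(=O)c1oc2nc(-c3cccs3)cc(C(F)(F)F)c2c1N` is still unmeasured, and its difference from compound 2 is a group of 2 heavy atoms (2 carbon; no ring) in place of a group of 9 heavy atoms (7 carbon, 1 nitrogen, 1 chlorine; one six-membered aromatic ring of carbon only), on an amide-type nitrogen. Going by the values given here, the only measured step, a 1.0-fold lower number from compound 1 to compound 2 (0.02 log units; within the scatter), is chloro in place of bromo on an aromatic carbon and lies within the scatter. Among the compounds with values here, that step leaves the amide-type nitrogen untouched, and no measured compound carries ethyl there, so the size of this much larger change is poorly constrained. The estimated change is a 1.1-fold higher number from compound 2 to compound 3 (0.04 log units; within the scatter), with no shift beyond the scatter expected and no direction favoured. For compound 3 the expected value is 90000 nM, with an estimated range of 30000 nM to 250000 nM.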

Compound 3, half-maximal inhibitory concentration: 62000 nM
Estimate against measurement, compound 3: 1.5-fold (0.16 log units) above; the measured number falls inside the stated range.
By their numbers in this assay, from the lowest: compounds 3, 2 and 1 (each within the scatter of the next).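

In this assay, the step of a 1.3-fold lower number from compound 2 to compound 3 (0.13 log units; within the scatter) and the step of a 1.4-fold lower number from compound 1 to compound 3 (0.14 log units; within the scatter) both replace a group carrying a six-membered aromatic ring of carbon only with ethyl on an amide-type nitrogen. Both steps lie within the scatter, so this position now has a direct reading: the loss of that ring and its double bond outside aromatic rings leaves no change that these numbers can resolve, whereas the earlier pair showed only a halogen exchange on that ring. No supporting measurement bears on this result.

As far as these compounds go, whether a longer chain such as butyl, or a chain ending in an amine or a carboxylic acid, on the amide-type nitrogen would move the number beyond the scatter remains open. Also open, from the compounds shown here alone, is whether the hydrogen alone on that nitrogen would do so.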